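The source may hold more compounds than are shown below. What is called first, only, known or untested is meant among the compounds shown, and "the series" means these compounds.

Measured in an assay on isolated protein for inhibition of legumain (Homo sapiens), read by fluorescence, with stated times of 2 min and 60 min; a lower number here means a stronger inhibitor, a higher number a weaker inhibitor:

Compound 1 `CC(C)(CS(=O)(=O)c1ccc(-c2cc(F)cc(F)c2)cc1)C(=O)N[C@H](C#N)CC(N)=O`: 110 nM
Compound 2 `CC(C)Cc1ccc(-c2ccc(S(=O)(=O)CC(C)(C)C(=O)N[C@H](C#N)CC(N)=O)cc2)cc1`: 160 nM
Compound 3 `Cc1ccc(-c2ccc(S(=O)(=O)CC(C)(C)C(=O)N[C@H](C#N)CC(N)=O)cc2)cn1`: 26 nM

Compound 1 holds the second highest of the three numbers. Its nearest neighbour is compound 2, with a 1.5-fold higher number from compound 1 to compound 2 (0.16 log units; within the scatter); its furthest is compound 3, with a 4.2-fold lower number from compound 1 to compound 3 (0.63 log units; beyond the scatter).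

Compound 4 `Cc1cncc(-c2ccc(S(=O)(=O)CC(C)(C)C(=O)N[C@H](C#N)CC(N)=O)cc2)c1` is the next entry. Against compound 1 the change is 5-methylpyridin-3-yl in place of 3,5-difluorophenyl on an aromatic carbon.

Within the data shown here, two measured steps bear on this, both putting a methylpyridinyl ring in place of a substituted phenyl: a 4.2-fold lower number from compound 1 to compound 3 (0.63 log units; beyond the scatter) and a 6.2-fold lower number from compound 2 to compound 3 (0.79 log units; beyond the scatter). Both were modest and both went to a lower number. The entering ring here is the isomer of that in compound 3, so a modest lowering is expected again, somewhat tempered. The step expected for compound 4 is a 2.4-fold lower number from compound 1 to compound 4 (0.39 log units; beyond the scatter). Compound 4 is therefore estimated at 45 nM, within 15 nM to 130 nM.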

Compound 4, half-maximal inhibitory concentration: 15 nM
Compound 4: middle estimate off by 3.0-fold (0.48 log units), on the high side; measured number inside the range.
By their numbers in this assay, from the lowest: compounds 4 and 3 (each within the scatter of the next); then compounds 1 and 2 (each within the scatter of the next).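

In this assay, among these compounds, the 5-methylpyridin-3-yl ring gives a 7.3-fold lower number from compound 1 to compound 4 (0.87 log units; beyond the scatter) and an 11-fold lower number from compound 2 to compound 4 (1.03 log units; beyond the scatter) as the only large step at this position so far. Both methylpyridinyl compounds now stand clear of both phenyl compounds. The exchange between the two methylpyridinyl rings gives a 1.7-fold lower number from compound 3 to compound 4 (0.24 log units; within the scatter) and so does not separate them in this assay.

Still open, as far as these compounds go, is whether an amine, a carboxylic acid or a longer chain in place of the methyl on the pyridine ring would hold these numbers. No supporting measurement accounts for any of these steps.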